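The source may hold more compounds than are shown below. What is called first, only, known or untested is meant among the compounds shown, and "the series" means these compounds.

Measured compounds, read in a functional assay on SK-N-SH cells (Homo sapiens) for cytotoxicity, read by MTT assay, with a stated time of 48 h; on this read-out higher numbers stand for weaker inhibition and lower numbers for stronger inhibition:
compound 1 `COc1cccc2[nH]cc(C3(c4c[nH]c5cccc(OC)c45)C(=O)Nc4ccccc43)c12` — 4700 nM
compound 2 `O=C1Nc2ccccc2C1(c1c[nH]c2ccc(Br)cc12)c1c[nH]c2ccc(Br)cc12` — 13200 nM
compound 3 `COc1cccc2[nH]cc(C3(c4c[nH]c5cccc(OC)c45)C(=O)Nc4ccc(F)cc43)c12` — 12100 nM

Compound 2 and compound 1 differ in more than one place; the difference between the two cores is not broken down here. The values of compound 2 and compound 3 in this assay lie within the scatter of each other, while compound 2 gives a number beyond the scatter above that of compound 1.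

One change is seen twice in the series. From compound 1 to compound 3 it is fluoro in place of hydrogen on an aromatic carbon, and it made a 2.6-fold higher number from compound 1 to compound 3 (0.41 log units; beyond the scatter). The same change, (fluoro in place of hydrogen on an aromatic carbon), turns compound 2 into compound 4 `O=C1Nc2ccc(F)cc2C1(c1c[nH]c2ccc(Br)cc12)c1c[nH]c2ccc(Br)cc12`, not yet measured. Compound 4 is expected to show a step of a 2.4-fold higher number from compound 2 to compound 4 (0.38 log units; beyond the scatter) in this assay, resting on the step of a 2.6-fold higher number from compound 1 to compound 3 (0.41 log units; beyond the scatter) seen in the other pair. For compound 4 the estimated number is 32000 nM, with a range from 13000 nM to 80000 nM.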

Compound 4, half-maximal inhibitory concentration: 2800 nM
Estimate against measurement, compound 4: 11-fold (1.06 log units) above; the whole stated range lies above it.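

In this assay, fluoro in place of hydrogen on an aromatic carbon gives a 4.7-fold lower number from compound 2 to compound 4 (0.67 log units; beyond the scatter) on the core of compound 2, the opposite direction to the step on the core of compound 1. The step measured on one core therefore did not predict the step on the other in this series, although two pairs give no rule for any further core and do not show which difference between the cores matters. The two steps are set side by side here: the same change on two cores in this assay, a 2.6-fold higher number (0.41 log units; beyond the scatter) from compound 1 to compound 3 and a 4.7-fold lower number (0.67 log units; beyond the scatter) from compound 2 to compound 4, 12-fold (1.08 log units) apart, beyond the scatter of two such steps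

The compounds shown leave open whether another group on the same aromatic carbon, such as chloro or an amine, would also give opposite steps on the two cores. They also leave open how a core carrying one methoxy group or one bromo group per indole-free comparison would respond, since only these two cores are shown.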